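Amide variation on a triazole dioxolane scaffold

The compounds below may be only part of what the source reports. "The series", "measured", "known", "first", "only" and "open" are said of these compounds alone.

Compound 1 `CCC(=O)Nc1ccc(N2CCN(c3ccc(OC[C@@H]4CO[C@@](Cn5cncn5)(c5ccc(Cl)cc5Cl)O4)cc3)CC2)cc1`: 5460 nM
Compound 2 `O=C(CCCCc1ccccc1)Nc1ccc(N2CCN(c3ccc(OC[C@@H]4CO[C@@](Cn5cncn5)(c5ccc(Cl)cc5Cl)O4)cc3)CC2)cc1`: 7010 nM

In a functional assay on HepG2 cells (Homo sapiens) for inhibition, read by MTT assay, with a stated time of 48 h (on this read-out higher numbers stand for weaker inhibition and lower numbers for stronger inhibition), compound 1 gives 5460 nM and compound 2 gives 7010 nM; the change a 1.3-fold higher number from compound 1 to compound 2 (0.11 log units; within the scatter) lies within the scatter, so neither compound can be ranked against the other. Compound 3 `O=C(Nc1ccc(N2CCN(c3ccc(OC[C@@H]4CO[C@@](Cn5cncn5)(c5ccc(Cl)cc5Cl)O4)cc3)CC2)cc1)c1cccc(F)c1` differs from compound 2 by 3-fluorophenyl in place of 4-phenylbutyl on a carbonyl carbon. Among the measured compounds shown here, only the single step from compound 1 to compound 2 bears on this amide position, and it showed no movement beyond the scatter. Compound 3 is therefore expected to sit near compound 2, with an estimated step of a 1.1-fold lower number from compound 2 to compound 3 (0.05 log units; within the scatter) and an estimated value of 6200 nM (range 2500 nM to 15000 nM).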

Compound 3, half-maximal inhibitory concentration: 10800 nM
Compound 3: the middle estimate sits 1.7-fold (0.24 log units) below what was measured; the measured number falls inside the stated range.
By their numbers in this assay, from the lowest: compounds 1, 2 and 3 (each within the scatter of the next).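

In this assay, among the compounds shown here, an aromatic 3-fluorophenyl on the carbonyl carbon replaces the chains of the earlier compounds, and both steps stay within the scatter: a 1.5-fold higher number from compound 2 to compound 3 (0.19 log units; within the scatter) and a 2.0-fold higher number from compound 1 to compound 3 (0.30 log units; within the scatter). Ethyl, 4-phenylbutyl and 3-fluorophenyl at this position thus give numbers that cannot be told apart, even across this change from chain to directly attached aromatic ring. No supporting data bear on this result. Still open, as far as these compounds go, is whether an unsubstituted phenyl, or an amine or carboxylic acid on the chain, would move the number beyond the scatter.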